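Replacing one aryl group with methyl on a quaternary carbon

A few compounds are considered here, and "the series" means these few. Any claim that something is new, unique, unknown or untested is made for them only; others in the source may bear on it.

Measured so far:
compound 1 `Cc1nccn1CC(C)C(C(N)=O)(c1ccccc1)c1ccccc1` with 2.89 nM;
compound 2 `Cc1nccn1CCC(CO)(c1ccccc1)c1ccccc1` with 25.4 nM;
compound 3 `Cc1ccc(C(CCn2ccnc2C)(C(N)=O)c2ccccc2)cc1` with 24.6 nM.

These three compounds were measured in an assay on ileum with muscarinic acetylcholine receptor M3 (Cavia porcellus) as the target; a lower number here means a stronger inhibitor, a higher number a weaker inhibitor. Among them, compound 3 gives the second highest number with 24.6 nM. Its nearest neighbour is compound 2, whose value of 25.4 nM lies within the scatter of compound 3, so no order between these two can be claimed. Its furthest neighbour is compound 1, which with 2.89 nM gives a number that is well beyond the scatter below that of compound 3.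

Compound 4 `Cc1nccn1CCC(C)(C(N)=O)c1ccccc1` has not yet been measured in this assay. It differs from compound 3 in one place: methyl in place of 4-methylphenyl on a saturated chain carbon bound to an aromatic carbon, a carbonyl carbon and a saturated chain carbon. Going by the values given here, no step between measured compounds shows this kind of change, so the expectation rests on the structures alone. All three measured compounds carry two aromatic rings on the same saturated chain carbon; compound 4 keeps only one. The expected step from compound 3 to compound 4 is a 12-fold higher number from compound 3 to compound 4 (1.09 log units; beyond the scatter), a move toward a weaker inhibitor that goes beyond the scatter. Compound 4 is therefore estimated to give 300 nM, with a range from 60 nM to 1500 nM.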

Compound 4, antagonist equilibrium constant: 1830 nM
For compound 4 the middle estimate is 6.1-fold (0.79 log units) below the measured one; measured number outside the range, above it.
By their numbers in this assay, from the lowest: compound 1; then compounds 3 and 2 (each within the scatter of the next); then compound 4.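

In this assay, methyl in place of 4-methylphenyl on a saturated chain carbon bound to an aromatic carbon, a carbonyl carbon and a saturated chain carbon gives a 74-fold higher number from compound 3 to compound 4 (1.87 log units; beyond the scatter) and is the only step shown at this position. Going by these compounds alone, all the earlier compounds keep two aromatic rings on this carbon, so they could not show what happens when one is lost; this large move toward a weaker inhibitor shows that the position does not accept the exchange of that ring for a single carbon without a heavy loss. The two groups differ in ring and carbon count alone, with no hydrogen-bond donor, acceptor or net charge on either side, and no measurement shown explains why the number rises this far.

A single step cannot separate the loss of the aromatic ring from the loss of size, and a cyclohexyl group or a longer chain at this place would be needed to tell the two apart. Also open, from the compounds shown here alone, is how a plain hydrogen in place of the methyl, or a plain phenyl in place of the 4-methylphenyl, would compare with these two compounds.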